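Bromo in place of chloro: an expected solubility

This account rests on a few compounds, and the source may have more. Where it says the series, first, only, none or still open, it means among the compounds named here.

Compound 1 `COc1cc(OC)c(/C=C/S(=O)(=O)Nc2ccc(OC)c(NC(C)C(=O)O)c2)c(OC)c1` gives 10000 ug/mL as its value
Compound 2 `COc1cc(OC)c(/C=C/S(=O)(=O)Nc2ccc(OC)c(NC(C(=O)O)c3ccc(Cl)cc3)c2)c(OC)c1` gives 10000 ug/mL as its value

Level with compound 1, compound 2 stands at 10000 ug/mL in a physicochemical assay for solubility (on this read-out higher numbers stand for higher solubility and lower numbers for lower solubility), on the numbers so far. Compound 3 `COc1cc(OC)c(/C=C/S(=O)(=O)Nc2ccc(OC)c(NC(C(=O)O)c3ccc(Br)cc3)c2)c(OC)c1` differs from it by bromo in place of chloro on an aromatic carbon, with bromo in place of chloro on an aromatic carbon. Within the data shown here, the only measured step that bears on this is no change at the digits printed from compound 1 to compound 2 (within the scatter) and it showed nothing beyond the scatter. On that evidence the expected size is no change at the digits printed from compound 2 to compound 3 (within the scatter) in this assay, with no step beyond the scatter expected in either direction. For compound 3 the estimated value is 10000 ug/mL, with an expected range from 5000 ug/mL to 20000 ug/mL on this read-out.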

Compound 3, solubility: 10000 ug/mL
Estimate against measurement, compound 3: no gap at the digits printed; the range from low to high includes it.
By their numbers in this assay, from the lowest: compounds 1, 2 and 3 (each within the scatter of the next).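

In this assay, bromo in place of chloro on this aromatic carbon, para to a large group, gives no change at the digits printed from compound 2 to compound 3 (within the scatter) and so adds a second halogen here that the read-out does not separate from the first. 4-Bromophenyl in place of methyl gives no change at the digits printed from compound 1 to compound 3 (within the scatter) and extends to a second aryl group what 4-chlorophenyl showed. Nothing available explains either result. As far as these compounds go, whether an amine or a nitrile on that aromatic carbon, or a longer chain in place of the methyl, would also leave the values level remains open.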